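Methoxybenzyl amino acid variant of the furanyl core

A few compounds are considered here, and "the series" means these few. Any claim that something is new, unique, unknown or untested is made for them only; others in the source may bear on it.

Two compounds from the series have measurements in an assay on CHO cells for displacement of a labelled ligand from adenosine receptor A1 (Homo sapiens); on this read-out lower numbers stand for stronger inhibition and higher numbers for weaker inhibition. Compound 1, `CNC(=O)c1cnc(NC(=O)NC2CCCCC2)n2nc(-c3ccco3)nc12`, a methyl amide bearing a cyclohexyl urea on the shared core, gives 8990 nM in this assay. Compound 2, `CNc1ncc(C(=O)O)c2nc(-c3ccco3)nn12`, carries a carboxylic acid and a methylamino group on the same core. In this assay compound 2 gives only a limit, > 100000 nM, and no number; this is the limit at the limit of > 100000 nM in this assay, at which 1 of the 2 values shown sits. Among the measured compounds shown here, compound 2 therefore stands at the weak end of what the assay can report, with no measured step to any other compound.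

Compound 3, `COc1ccc(CNc2ncc(C(=O)O)c3nc(-c4ccco4)nn23)cc1`, differs from compound 2 in one place: 4-methoxyphenyl in place of hydrogen on a saturated chain carbon bound to a nitrogen on an aromatic ring. The acid and the amino attachment are kept. For the measured compounds named here, no measured step from a hydrogen to an aryl group exists, so the direction of the step in this assay is open; any gain would have to carry compound 3 back from the limit into the measurable range. Compound 3 is estimated at 40000 nM, within 8000 nM to 200000 nM, which means an expected step of an at least 2.5-fold lower number from compound 2 to compound 3 (0.39 log units; beyond the scatter).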

Compound 3, inhibition constant: 5760 nM
Compound 3: the middle estimate sits 6.9-fold (0.84 log units) above what was measured; the whole stated range lies above it.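

The carboxylic acid does not by itself hold a compound at the weak end of this assay: with the acid kept, 4-methoxyphenyl in place of hydrogen on a saturated chain carbon bound to a nitrogen on an aromatic ring gives an at least 17-fold lower number from compound 2 to compound 3 (1.23 log units; beyond the scatter). Compound 2 gives only a limit, > 100000 nM, and not a number, so the step is a bound and its full size cannot be read. Even so, this is the only place in the compounds shown where a change in one place is seen to move the read-out, and it moves by more than the usual scatter.

The compounds shown do not separate the contribution of the aryl ring from that of its methoxy group, which an unsubstituted benzyl group on the same nitrogen would do. They also leave open whether the exchange of methyl for 4-methoxybenzyl gives a step of similar size when a primary amide or an ester stands in place of the carboxylic acid.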